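Compound 2 and Its Ethynyl Counterpart, Compound 4

The source may hold more compounds than are shown below. What is called first, only, known or untested is meant among the compounds shown, and "the series" means these compounds.

Of the compounds shown here, three have been measured in a functional assay on KETR3 cells (Homo sapiens) for inhibition, read by MTT assay, with a stated time of 120 h; on this read-out lower numbers stand for stronger inhibition and higher numbers for weaker inhibition. Compound 1 `C/C(=C\c1ccc(NC(=O)Nc2ccc(Cl)c(C(F)(F)F)c2)cc1)C(=O)NC(C)c1ccccc1` gives > 50000 nM, which is a limit of the assay and not a number. Compound 2 `CNC(=O)/C(C)=C/c1ccc(NC(=O)Nc2ccc(Cl)c(C(F)(F)F)c2)cc1` gives > 50000 nM, which is likewise a limit and not a number. Compound 3 `CC(NC(=O)/C=C/Oc1ccc(NC(=O)Nc2ccc(Cl)c(C(F)(F)F)c2)cc1)c1ccccc1` gives a true number, 14500 nM.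

Compound 2 therefore has no exact place in the series and stands at the limit of > 50000 nM in this assay, at which 2 of the 3 values shown sit. Compound 4 `CNC(=O)C#Cc1ccc(NC(=O)Nc2ccc(Cl)c(C(F)(F)F)c2)cc1` is related to it by one structural change: 2-(methylcarbamoyl)ethynyl in place of 2-(methylcarbamoyl)prop-1-en-1-yl on an aromatic carbon. The new group, 2-(methylcarbamoyl)ethynyl, sits on an aromatic carbon, para to a large group, where 2-(methylcarbamoyl)prop-1-en-1-yl stood before.

Within the data shown here, the only measured step is a step that the two limits leave unreadable from compound 1 to compound 2, and it concerns a different place in the structure, so it offers no size to carry over. The expectation therefore rests on compound 2, whose > 50000 nM is a limit, and no large gain is expected in this assay. The expected change is an at least 1.2-fold lower number from compound 2 to compound 4 (0.09 log units; that floor lies within the scatter), with no firm direction beyond the scatter. For compound 4 the estimated value is 40000 nM, with an expected range from 15000 nM to 100000 nM.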

Compound 4, half-maximal inhibitory concentration: 24700 nM
For compound 4 the middle estimate is 1.6-fold (0.21 log units) above the measured one; low and high end bracket the measured number.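

In this assay, among these compounds, compound 4 gives a true number, which none of the compounds with 2-(methylcarbamoyl)prop-1-en-1-yl on this aromatic carbon, para to a large group, has given, and so 2-(methylcarbamoyl)ethynyl at this place is the first group there with a readable value. The reading for compound 2 remains a limit and not a number: the limit of > 50000 nM in this assay, at which 2 of the 4 values shown sit. The change from 2-(methylcarbamoyl)prop-1-en-1-yl to 2-(methylcarbamoyl)ethynyl is therefore known only as a floor, an at least 2.0-fold lower number from compound 2 to compound 4 (0.30 log units; that floor lies within the scatter) and the real size of the step may be larger, while the data give no reason for it.

The step between the two limits, from compound 1 to compound 2, cannot be read, so the compounds shown do not tell whether 1-phenylethyl in place of methyl on the amide nitrogen would move the number of compound 4 in either direction. On these data alone, it also remains open how this aromatic position would respond to a nitrile or a carboxylic acid in place of the methylcarbamoyl part of the 2-(methylcarbamoyl)ethynyl group.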